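The compounds below may be only part of what the source reports. "The series", "measured", "known", "first", "only" and "open" are said of these compounds alone.

In a functional assay on THP-1 cells (Homo sapiens) for inhibition, read by luminescence, with a stated time of 72 h, tested at 5 uM (a higher number here means more inhibition of growth at the concentration tested, a lower number less inhibition of growth), compound 1 `C=CS(=O)(=O)NC/C=C/c1cc(OC)cc(O)c1C(=O)OCC(C)c1ccccc1` gives 5.6% and compound 2 `COc1cc(O)c(C(=O)OCC(C)c2ccccc2)c(/C=C/CN2C(=O)C=CC2=O)c1` gives 0% of growth inhibition, two numbers within the scatter of each other. Compound 3 `C=CS(=O)(=O)NC/C=C/c1cc(OC)cc(O)c1C(=O)OCc1ccc(F)cc1` reaches 41.7% and so stands clearly above compound 2, beyond the scatter. Compound 2 therefore sits at the low end of this small set, level with compound 1.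

Compound 4 `COc1cc(O)c(C(=O)OCC2CCCCC2)c(/C=C/CN2C(=O)C=CC2=O)c1` departs from compound 2 at one place. The change, (cyclohexyl in place of 1-phenylethyl on a saturated chain carbon bound to an oxygen next to a carbonyl group), puts cyclohexyl in place of 1-phenylethyl on a saturated chain carbon bound to an oxygen next to a carbonyl group.

Among the measured compounds shown here, two measured steps bear on this. The large one, a number 36.1 percentage points higher from compound 1 to compound 3 (beyond the scatter), replaced the same 1-phenylethyl at the same place, though with 4-fluorophenyl and with a different group elsewhere in the molecule. For the measured compounds named here, the other, a number 5.6 percentage points lower from compound 1 to compound 2 (within the scatter), changed only that other group. Going by the values given here, no measured compound carries cyclohexyl, and 4-fluorophenyl holds an aromatic ring while cyclohexyl does not, so only part of the large step is expected to carry over. The expected step in this assay is upward, estimated as a number 15 percentage points higher from compound 2 to compound 4 (beyond the scatter) and smaller than the large one. The estimate for compound 4 is 15% with an expected range from 0% to 40% in this measurement.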

Compound 4, percent growth inhibition at one concentration: 5.9%
Compound 4: the middle estimate sits 9.1 percentage points above what was measured, within the range that was stated.
By their numbers in this assay, from the lowest: compounds 2, 1 and 4 (each within the scatter of the next); then compound 3.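

Within this assay, cyclohexyl in place of 1-phenylethyl on a saturated chain carbon bound to an oxygen next to a carbonyl group gives a number 5.9 percentage points higher from compound 2 to compound 4 (within the scatter), so with the rest of compound 2 kept, a non-aromatic ring of carbon only, with 6 heavy atoms against 8, reads level with the group it replaces. Among the compounds shown here, until now the only change seen at this place was a number 36.1 percentage points higher from compound 1 to compound 3 (beyond the scatter), with a different group elsewhere in the molecule, and the new step shows that a replacement of 1-phenylethyl here does not always come with a large step. Nothing shown here gives a measured reason for either result.

Still open, going by these compounds, is whether 4-fluorophenyl would give a large step on the rest of compound 2, and whether cyclohexyl would read differently alongside the group that compounds 1 and 3 carry elsewhere in the molecule. On these data alone, how a plain phenyl, a 4-chlorophenyl or a piperidine ring would read at this same place also remains unknown.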